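Moving one chlorine from compound 2 to compound 4

The source may report more compounds than this note shows. Statements on the series, on what has been measured and on what is new or still open speak of the compounds shown alone.

In a functional assay on T98G cells (Homo sapiens) for inhibition, read by MTT assay, with a stated time of 72 h (on this read-out lower numbers stand for stronger inhibition and higher numbers for weaker inhibition), compound 1 (`CC1(C)CC(NC(=S)Nc2cccc([N+](=O)[O-])c2)c2cc(Br)ccc2O1`) reads 4000 nM while compound 2 (`CC1(C)CC(NC(=S)Nc2cccc(Cl)c2)c2cc(Br)ccc2O1`) reads 9000 nM and compound 3 (`CC1(C)CC(NC(=S)NCc2ccccc2)c2cc(Cl)ccc2O1`) reads 99000 nM as the highest number, which leaves compound 2 in the middle of the three. Compound 4 (`CC1(C)CC(NC(=S)Nc2ccccc2Cl)c2cc(Br)ccc2O1`) is still unmeasured and holds the same atoms as compound 2, joined differently (2-chlorophenyl in place of 3-chlorophenyl on an amide-type nitrogen): 2-chlorophenyl in place of 3-chlorophenyl on an amide-type nitrogen. Among the measured compounds shown here, no measured step moves a chlorine in this way. The nearest evidence is a swap on an aromatic carbon (a 2.3-fold higher number from compound 1 to compound 2 (0.35 log units; beyond the scatter)) that was modest. In this assay a step no larger than that is therefore expected, probably none beyond the scatter, with no direction favoured. The estimated step is small (no change at the digits printed from compound 2 to compound 4 (within the scatter)). Compound 4 is expected to read 9000 nM within an estimated range (3500 nM to 23000 nM).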

Compound 4, half-maximal inhibitory concentration: 8000 nM
For compound 4 the middle estimate is 1.1-fold (0.05 log units) above the measured one, within the range that was stated.
By their numbers in this assay, from the lowest: compounds 1, 4 and 2 (each within the scatter of the next, the first and the last beyond it); then compound 3.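

Moving the chlorine from 3-chlorophenyl to 2-chlorophenyl on the amide-type nitrogen gives a 1.1-fold lower number from compound 2 to compound 4 (0.05 log units; within the scatter) in this assay. The earlier compounds shown here changed which group was present or the wider structure, whereas this pair changes only where the chlorine is attached, and that shift stays within the scatter. Nothing measured here explains this result.

Going by these compounds, whether an amine or a carboxylic acid in place of the chlorine would read differently stays open. So does whether the same shift of a methoxy group would also stay within the scatter.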